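Fluoro for methyl, carried onto a second core

A few compounds are considered here, and "the series" means these few. Any claim that something is new, unique, unknown or untested is made for them only; others in the source may bear on it.

Measured in a functional assay on NCI-H460 cells (Homo sapiens) for cytotoxicity, read by MTT assay, with a stated time of 72 h; a lower number here means a stronger inhibitor, a higher number a weaker inhibitor:
compound 1, `COc1cc2c(Oc3ccc(NC(=O)c4cc(-c5ccc(F)cc5)ccn4)cc3F)ccnc2cc1OCCCN1CCCCC1`, gives 250 nM
compound 2, `COc1cc2c(Oc3ccc(NC(=O)c4cc(-c5ccc(C)cc5)ccn4)cc3F)ccnc2cc1OCCCN1CCCCC1`, gives 160 nM
compound 3, `COc1cc2c(Oc3ccc(NC(=O)c4nccc(-c5ccc(C)cc5)n4)cc3F)ccnc2cc1OCCCN1CCN(C)CC1`, gives 160 nM

Compound 2 and compound 1 share one core and differ in one place, (fluoro in place of methyl on an aromatic carbon). That step reads a 1.6-fold higher number from compound 2 to compound 1 (0.19 log units; within the scatter). Compound 3 sits on a different core; the difference between the core of compound 3 and the core of compound 2 is not broken down here. Compound 3 and compound 2 read level at the digits given, so nothing separates them within the scatter.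

Compound 4, `COc1cc2c(Oc3ccc(NC(=O)c4nccc(-c5ccc(F)cc5)n4)cc3F)ccnc2cc1OCCCN1CCN(C)CC1`, is not yet measured. It differs from compound 3 by fluoro in place of methyl on an aromatic carbon. The place described is the same word for word as for the change from compound 2 to compound 1, so this is the same change made a second time, now on the core of compound 3.

The step from compound 3 to compound 4 in this assay is expected to be a 1.6-fold higher number from compound 3 to compound 4 (0.19 log units; within the scatter), resting on the earlier step of a 1.6-fold higher number from compound 2 to compound 1 (0.19 log units; within the scatter) and on compound 3 at 160 nM. Compound 4 is estimated at 250 nM, between 120 nM and 520 nM. Among the measured compounds shown here, with only one earlier instance of the change, the range is kept wide.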

Compound 4, half-maximal inhibitory concentration: 63 nM
Compound 4: the middle estimate sits 4.0-fold (0.60 log units) above what was measured; the measured number lies below the stated range.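

In this assay, 4-methylphenyl to 4-fluorophenyl on the core of compound 3 gives a 2.5-fold lower number from compound 3 to compound 4 (0.40 log units; beyond the scatter), a modest step, and the change does not carry over with the same outcome from the core of compound 2: the same change on two cores in this assay, a 1.6-fold higher number (0.19 log units; within the scatter) from compound 2 to compound 1 and a 2.5-fold lower number (0.40 log units; beyond the scatter) from compound 3 to compound 4, 4.0-fold (0.60 log units) apart, beyond the scatter of two such steps

On the core of compound 2 the change stays within the scatter, whereas on the core of compound 3 it goes beyond it, so in this series the reading on one core does not predict the reading on the other. This does not show which part of the difference between the cores matters, and with one pair on each core it establishes no general rule for either core.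

Open, as far as these compounds go, is whether the gap between the cores persists with other groups at the same place, such as chloro, methoxy or a nitrile. Also open, from the compounds shown here alone, is how an amine or a carboxylic acid at that place would read on each core.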